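The compounds below may be only part of what the source reports. "The series", "measured", "known", "first", "only" and "open" are said of these compounds alone.

Working notes on the series, all in a functional assay (trachea) with Cavia porcellus as the target; a higher number here means a weaker inhibitor, a lower number a stronger inhibitor. Compound 1 `C=CCn1nc(-c2cccnc2)c2ccccc2c1=O` gives 2140 nM, compound 2 `COCCn1nc(-c2cccnc2)c2ccccc2c1=O` gives 9330 nM and compound 3 `O=C(O)c1ccc(Cn2nc(-c3cccnc3)c3ccccc3c2=O)cc1` gives 17000 nM. Compound 3 stands level with compound 2 within the scatter, as a 1.8-fold higher number from compound 2 to compound 3 (0.26 log units; within the scatter) shows. Both stand clear of compound 1, with a 4.4-fold higher number from compound 1 to compound 2 (0.64 log units; beyond the scatter) and a 7.9-fold higher number from compound 1 to compound 3 (0.90 log units; beyond the scatter).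

Compound 4 `CC(C)NC(=O)CCCn1nc(-c2cccnc2)c2ccccc2c1=O` comes next, with the change (2-(isopropylcarbamoyl)ethyl in place of 4-carboxyphenyl on a saturated chain carbon bound to an aromatic nitrogen). That is 2-(isopropylcarbamoyl)ethyl in place of 4-carboxyphenyl on a saturated chain carbon bound to an aromatic nitrogen.

Among the compounds with values here, no measured compound carries this amide chain, so only the steps at this same place bear on it, and these are modest at most. Compound 1 and compound 2 have no 4-carboxyphenyl, and the two steps leading to compound 3 from them both end at a higher number, one within the scatter and one beyond it. A modest drop is therefore expected, estimated as a 2.6-fold lower number from compound 3 to compound 4 (0.42 log units; beyond the scatter). For compound 4 the expected value is 6500 nM, with an estimated range of 2200 nM to 19000 nM.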

Compound 4, half-maximal inhibitory concentration: 64600 nM
Beside the measured number, compound 4's estimate is 9.9-fold (1.00 log units) below it; the measured number lies above the stated range.
By their numbers in this assay, from the lowest: compound 1; then compounds 2 and 3 (each within the scatter of the next); then compound 4.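

Compound 4 is the weakest inhibitor of the four in this assay. It stands clear of the 4-carboxyphenyl group of compound 3 (a 3.8-fold higher number from compound 3 to compound 4 (0.58 log units; beyond the scatter)), the methoxy-ended chain of compound 2 (a 6.9-fold higher number from compound 2 to compound 4 (0.84 log units; beyond the scatter)) and the vinyl-ended chain of compound 1 (a 30-fold higher number from compound 1 to compound 4 (1.48 log units; beyond the scatter)), the last being the largest step in the series. At this place, on a saturated chain carbon bound to an aromatic nitrogen, the two groups without a ring in compounds 1 and 4 now mark the two ends of the series, with the ring-bearing group of compound 3 lying between them, and no measurement shown explains this result.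

On these data alone, whether the rise follows the amide or the chain length stays open; a plain butyl chain or a primary amide on the same chain would separate the two. An unsubstituted benzyl group would likewise show what the carboxylic acid contributes in compound 3.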